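This account rests on a few compounds, and the source may have more. Where it says the series, first, only, none or still open, it means among the compounds named here.

Compound 1 `COc1cc(C2OC(c3ccccc3N(C)C)=NN2C(C)=O)cc(OC)c1OC` gives 109 uM
Compound 2 `COC(=O)N1N=C(c2ccc(N(C)C)cc2)OC1c1cc(OC)c(OC)c(OC)c1` gives 106 uM

Both numbers come from a functional assay on NCI-H460 cells (Homo sapiens) (a higher number here means that more compound is needed for the effect, a lower number that less compound is needed), and lie within the usual scatter of each other, so compound 2 stands level with compound 1. Compound 3 `COc1cc(C2OC(c3ccc(N(C)C)cc3)=NN2C(=O)CO)cc(OC)c1OC` is compound 2 with one change, hydroxymethyl in place of methoxy on a carbonyl carbon. Among the compounds with values here, no measured pair of compounds shows this change, so the expected step (a 1.2-fold lower number from compound 2 to compound 3 (0.07 log units; within the scatter)) stays within the scatter, and no clear direction is expected. Compound 3 is estimated at 90 uM (expected range from 35 uM to 200 uM).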

Compound 3, concentration for half-maximal effect: 0.043 uM
For compound 3 the middle estimate is 2100-fold (3.32 log units) above the measured one; measured number outside the range, below it.
By their numbers in this assay, from the lowest: compound 3; then compounds 2 and 1 (each within the scatter of the next).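

In this assay, replacing methoxy with hydroxymethyl on a carbonyl carbon gives a 2500-fold lower number from compound 2 to compound 3 (3.39 log units; beyond the scatter). Compounds 1 and 2 gave no hint that this position could matter so much. The two groups have the same atoms joined differently, yet this small rearrangement, which brings a hydrogen-bond donor that methoxy lacks, separates a weak compound from a far stronger one. Still open, on these data alone, is whether an amine, a carboxylic acid or a longer chain ending in hydroxyl on this carbonyl carbon would keep so low a number. No measurement at hand explains the size of this step.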